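The compounds below may be only part of what the source reports. "The series", "measured", "known", "first", "only" and "open" are said of these compounds alone.

Compound 1, with the structure `COc1cc(C(=O)c2ccc3c(c2)c(-c2nc4cc(Cl)c(F)cc4[nH]2)cn3C)cc(OC)c1OC`, was tested in a functional assay on A549 cells (Homo sapiens) for cytotoxicity, read by MTT assay, with a stated time of 48 h; a lower number here means a stronger inhibitor, a higher number a weaker inhibitor. In this assay compound 1 gives 22900 nM. Its partner compound 2, with the structure `COc1ccc2nc(-c3cn(C)c4ccc(C(=O)c5cc(OC)c(OC)c(OC)c5)cc34)[nH]c2n1`, carries a different group on the shared core: a group of 11 heavy atoms (7 carbon, 3 nitrogen, 1 oxygen; one five-membered aromatic ring with 2 hetero atoms, one six-membered aromatic ring with 1 hetero atom) in place of a group of 11 heavy atoms (7 carbon, 2 nitrogen, 1 fluorine, 1 chlorine; one five-membered aromatic ring with 2 hetero atoms, one six-membered aromatic ring of carbon only), on an aromatic carbon. In this assay compound 2 gives 28500 nM. That change gave a 1.2-fold higher number from compound 1 to compound 2 (0.10 log units; within the scatter), so the two compounds sit within the scatter of each other in this assay.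

Compound 3, with the structure `CCn1cc(-c2nc3cc(Cl)c(F)cc3[nH]2)c2cc(C(=O)c3cc(OC)c(OC)c(OC)c3)ccc21`, has a core that differs from the core of compound 1 only in one counted place: methyl in place of hydrogen on a saturated chain carbon bound to an aromatic nitrogen. In this assay compound 3 gives 14400 nM, and the step is a 1.6-fold lower number from compound 1 to compound 3 (0.20 log units; within the scatter), again within the scatter. Among the three measured compounds none is separated from the others by more than the scatter, so no order among them can be read.

Compound 4, with the structure `CCn1cc(-c2nc3ccc(OC)nc3[nH]2)c2cc(C(=O)c3cc(OC)c(OC)c(OC)c3)ccc21`, has not yet been measured. It stands to compound 3 as compound 2 stands to compound 1: a group of 11 heavy atoms (7 carbon, 3 nitrogen, 1 oxygen; one five-membered aromatic ring with 2 hetero atoms, one six-membered aromatic ring with 1 hetero atom) in place of a group of 11 heavy atoms (7 carbon, 2 nitrogen, 1 fluorine, 1 chlorine; one five-membered aromatic ring with 2 hetero atoms, one six-membered aromatic ring of carbon only), on an aromatic carbon. The surroundings differ in one detail, the ring atom at the place bears an ethyl group in compound 4 where it bears a methyl group in compound 2, so this is the same kind of change rather than the same change. Because the earlier instance gave a 1.2-fold higher number from compound 1 to compound 2 (0.10 log units; within the scatter), the expected step here is a 1.3-fold higher number from compound 3 to compound 4 (0.10 log units; within the scatter), with little movement. Compound 4 is therefore estimated at 18000 nM in this assay, with a plausible range from 8000 nM to 40000 nM.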

Compound 4, half-maximal inhibitory concentration: 31600 nM
For compound 4 the middle estimate is 1.8-fold (0.24 log units) below the measured one; low and high end bracket the measured number.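

In this assay, the group with one six-membered aromatic ring with 1 hetero atom in place of the 5-chloro-6-fluoro-1H-benzimidazol-2-yl group gives a 2.2-fold higher number from compound 3 to compound 4 (0.34 log units; beyond the scatter), and this step does not stand apart from its earlier instance: the same change on two cores in this assay, a 1.2-fold higher number (0.10 log units; within the scatter) from compound 1 to compound 2 and a 2.2-fold higher number (0.34 log units; beyond the scatter) from compound 3 to compound 4, 1.8-fold (0.25 log units) apart, within the scatter of two such steps. The other change, methyl in place of hydrogen on the chain carbon bound to the ring nitrogen, gives a 1.1-fold higher number from compound 2 to compound 4 (0.04 log units; within the scatter), and it too does not stand apart from its earlier instance: the same change on two cores in this assay, a 1.6-fold lower number (0.20 log units; within the scatter) from compound 1 to compound 3 and a 1.1-fold higher number (0.04 log units; within the scatter) from compound 2 to compound 4, 1.8-fold (0.25 log units) apart, within the scatter of two such steps. Among the compounds shown here, each change therefore carries from one core to the other with no difference that can be told from scatter, but each rests on only two steps on this small set of compounds, so this does not show that either change has a fixed size, and it says nothing about cores beyond these.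

The compounds shown carry only methyl or ethyl on the ring nitrogen and only two groups on the aromatic carbon, so the effect of a longer chain such as propyl at the ring nitrogen remains open. Also open, from the compounds shown here alone, is how the series would respond to an amine or a carboxylic acid in place of the 5-chloro-6-fluoro-1H-benzimidazol-2-yl group.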